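The source may hold more compounds than are shown below. What is called first, only, known or untested is meant among the compounds shown, and "the series" means these compounds.

Measured compounds, with their values in an assay on MDA-MB-231 cells for binding affinity to C-X-C chemokine receptor type 4 (Homo sapiens), read by immunofluorescence and microscopy, with stated times of 10 min and 30 min; a higher number here means that more compound is needed for the effect, a lower number that less compound is needed:

- compound 1 `O=C(NCc1ccc(CNS(=O)(=O)c2ccccc2)cc1)c1c(Cl)cc(Cl)cc1Cl`, which gives 10 nM
- compound 2 `Cc1ccc(S(=O)(=O)NCc2ccc(CNC(=O)c3cccc(Cl)c3)cc2)cc1`, which gives 100 nM
- compound 3 `O=C(NCc1ccc(CNS(=O)(=O)c2ccccc2)cc1)c1cccc(Cl)c1`, which gives 1000 nM

Among these three, compound 2 stands in the middle: compound 1 needs less compound (a 100-fold higher number from compound 1 to compound 3 (2.00 log units; beyond the scatter) shows how far the aryl group on the carbonyl carbon can move the result), and compound 3 needs more, as a 10-fold higher number from compound 2 to compound 3 (1.00 log units; beyond the scatter) shows for the loss of the methyl group alone.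

Compound 4 `Cc1ccc(S(=O)(=O)NCc2ccc(CNC(=O)c3cccnc3)cc2)cc1` keeps the methyl group of compound 2 and changes the other end: pyridin-3-yl in place of 3-chlorophenyl on a carbonyl carbon. Among the compounds with values here, no measured step here swaps the aryl group for a ring containing a nitrogen, so the nearest guide is the large step from compound 1 to compound 3, where chlorines on that ring were lost and the number rose steeply. Since the last chlorine is lost in compound 4, the step of a 10-fold higher number from compound 2 to compound 4 (1.00 log units; beyond the scatter) is expected to be toward a higher number. Compound 4 is therefore estimated at 1000 nM, within a range of 200 nM to 5000 nM.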

Compound 4, effective concentration (reported as EC, without a stated level of effect): > 1000 nM
Compound 4 gave a limit, no number; the forecaster's own chance of this, stated with the estimate: 15%; the middle value sits exactly at the limit.
By their numbers in this assay, from the lowest: compound 1; then compound 2; then compound 3.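

For compound 4 the result is a limit of the assay and not a number: the limit of > 1000 nM in this assay, at which 1 of the 4 values shown sits.

Even so, pyridin-3-yl in place of 3-chlorophenyl on a carbonyl carbon can be read as a step, an at least 10-fold higher number from compound 2 to compound 4 (1.00 log units; beyond the scatter), and its true size may be larger. The earlier compounds shown here showed only a change in the chlorines on a carbon-only ring at this place, whereas this step shows that a ring containing a nitrogen, with no chlorine, does not hold the number of compound 2.

The compounds shown leave open whether the loss of the chlorine or the arrival of the ring nitrogen carries this step, a question that an unsubstituted phenyl group at this place would help to separate. From the compounds shown here alone, how far compound 4 lies past its limit also stays open.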